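The source may report more compounds than this note shows. Statements on the series, on what has been measured and on what is new or still open speak of the compounds shown alone.

Of the compounds shown here, three sharing one core have been measured in a functional assay on A549 cells (Homo sapiens) for inhibition, read by MTT assay, with a stated time of 72 h; a lower number here means a stronger inhibitor, a higher number a weaker inhibitor. Compound 1 `COc1cccc(NC(=O)C2CCN(C/C=C/c3ccccc3)CC2)c1` gives 50500 nM there, the second highest of the three numbers. Its nearest neighbour is compound 3 `O=C(Nc1cccc2cccnc12)C1CCN(C/C=C/c2ccccc2)CC1`, which gives 51600 nM in this assay; the two values lie within the scatter of each other, so nothing separates them. The furthest is compound 2 `O=C(Nc1cccc(C(F)(F)F)c1)C1CCN(C/C=C/c2ccccc2)CC1`, which gives 15600 nM in this assay. For the measured compounds named here, that gap is the only single-point step on record: a 3.2-fold lower number from compound 1 to compound 2 (0.51 log units; beyond the scatter).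

Compound 4 `O=C(NCc1ccccc1)C1CCN(C/C=C/c2ccccc2)CC1` has not yet been measured. It differs from compound 1 as follows: benzyl in place of 3-methoxyphenyl on an amide-type nitrogen. The measured step from compound 1 to compound 2 swaps one group on the aromatic ring that hangs from the amide nitrogen. Here the aromatic ring itself is replaced by benzyl, so that step bears only loosely on this change. Going by the values given here, no measured step covers this kind of exchange, and with a modest shift the only change seen, there is no ground to expect a large move in either direction.

Compound 4 is therefore expected to give about 45000 nM in this assay, somewhere between 15000 nM and 140000 nM, which amounts to an estimated step of a 1.1-fold lower number from compound 1 to compound 4 (0.05 log units; within the scatter).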

Compound 4, half-maximal inhibitory concentration: > 100000 nM
Compound 4 was reported as a limit (the forecaster's own chance of this, stated with the estimate: 15%); middle value at least 2.2-fold (0.34 log units) away from the limit.
By their numbers in this assay, from the lowest: compound 2; then compounds 1 and 3 (each within the scatter of the next). At a limit, above all of these: compound 4.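

Compound 4 gives > 100000 nM in this assay, and this is a limit of the assay, not a number. For the compounds shown here, until now, the amide-type nitrogen had carried only aromatic rings bound directly to it, so this is the first look at benzyl there, and the exchange gives no lower number: the record reads an at least 1.9-fold higher number from compound 1 to compound 4 (0.29 log units; that floor lies within the scatter). On these data alone, that floor alone does not separate the two compounds, and the real size of the step stays unknown because the reading ends at a limit: the limit of > 100000 nM in this assay, at which 1 of the 4 values shown sits.

The exchange also changes two things at once, since the methoxy group goes and the ring is attached through benzyl, so the compounds shown cannot say which of these matters, and plain phenyl on the same nitrogen would help to separate them. They also leave open how a longer chain such as 2-phenylethyl, or an amine or a carboxylic acid on the benzyl ring, would behave in this assay.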